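A few compounds are considered here, and "the series" means these few. Any claim that something is new, unique, unknown or untested is made for them only; others in the source may bear on it.

Working notes on the series in a functional assay on PC-3 cells (Homo sapiens) for inhibition, read by MTT assay, with a stated time of 24 h; on this read-out higher numbers stand for weaker inhibition and lower numbers for stronger inhibition.

Compound 1 is `C/C=C/C(=O)CC1c2cc(OCc3cc(C)cc(C)c3)c(OCc3cc(C)cc(C)c3)cc2CCN1C(=O)OC(C)(C)C`. In this assay compound 1 reaches only the limit of the measurement, > 20000 nM, and no number is obtained for it. Compound 2 is `CCC[C@@H]1C[C@H](O)C/C=C(/CC)[C@H]2c3cc(OCc4ccccc4)c(OCc4ccccc4)cc3CCN12`; in this assay compound 2 also stops at the limit, > 20000 nM. Compound 3 is `CCC[C@@H]1CC(=O)C/C=C(/CC)[C@H]2c3cc(OCc4ccccc4)c(OCc4ccccc4)cc3CCN12`; in this assay compound 3 likewise gives the limit, > 20000 nM. Going by the values given here, compound 1 therefore stands nowhere on a scale of numbers: every value in the set is a limit, as summarised by the limit of > 20000 nM in this assay, at which 3 of the 3 values shown sit, and no step between two measured compounds can be stated.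

Compound 4 is `CCOC1c2cc(OCc3cc(C)cc(C)c3)c(OCc3cc(C)cc(C)c3)cc2CCN1C(=O)OC(C)(C)C`. Relative to compound 1 the change is ethoxy in place of ((prop-1-en-1-yl)carbonyl)methyl on a saturated ring carbon. Among the compounds with values here, with no measured step in the set and nothing beyond a limit for compound 1, there is no ground to expect a step of any direction beyond the scatter; the expectation is that compound 4, like compound 1, is most likely reported as a limit rather than a number. The estimated step from compound 1 to compound 4 is a step that the limit leaves unreadable from compound 1 to compound 4. Compound 4 is estimated at 30000 nM, with a range from 10000 nM to 100000 nM.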

Compound 4, half-maximal inhibitory concentration: > 20000 nM
Compound 4 was reported as a limit (the forecaster's own chance of this, stated with the estimate: 80%); the middle value does not contradict the limit.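

No step can be read between compound 1 and compound 4 in this assay, and every value in the set remains a limit: the limit of > 20000 nM in this assay, at which 4 of the 4 values shown sit.

The compounds shown leave open whether ethoxy in place of ((prop-1-en-1-yl)carbonyl)methyl on a saturated ring carbon changes inhibition at all, and how these compounds would rank on a scale of numbers.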